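The source may report more compounds than this note shows. Statements on the series, on what has been measured and on what is new or still open speak of the compounds shown alone.

Measured in a functional assay on CWR22R cells (Homo sapiens) for antiproliferative activity, read by propidium iodide staining, with a stated time of 96 h; on this read-out lower numbers stand for stronger inhibition and higher numbers for weaker inhibition:
- Compound 1 `CC(O)(CS(=O)(=O)c1ccccc1C(F)(F)F)C(=O)Nc1ccc(S(F)(F)(F)(F)F)cc1`: 17400 nM
- Compound 2 `CC(O)(CS(=O)(=O)c1ccc(OC(F)(F)F)cc1)C(=O)Nc1ccc(S(F)(F)(F)(F)F)cc1`: 51900 nM
- Compound 3 `CC(O)(CS(=O)(=O)c1cccc(OC(F)(F)F)c1)C(=O)Nc1ccc(S(F)(F)(F)(F)F)cc1`: 22400 nM

These three compounds share one core and differ only in the aromatic group on a sulfonyl sulfur. Compound 3 cannot be told apart from one of its neighbours, as there is a 1.3-fold higher number from compound 1 to compound 3 (0.11 log units; within the scatter). It stands clearly apart from the other, with a 2.3-fold lower number from compound 2 to compound 3 (0.36 log units; beyond the scatter).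

Compound 4 `CC(O)(CS(=O)(=O)c1ccccc1OC(F)(F)F)C(=O)Nc1ccc(S(F)(F)(F)(F)F)cc1` has not yet been measured. It has the same atoms as compound 3, joined differently: 2-(trifluoromethoxy)phenyl in place of 3-(trifluoromethoxy)phenyl on a sulfonyl sulfur. In words, 2-(trifluoromethoxy)phenyl replaces 3-(trifluoromethoxy)phenyl on a sulfonyl sulfur.

Among the measured compounds shown here, no measured step makes exactly this change, so two steps serve as indirect guides. Changing the position of the trifluoromethoxy group has mattered once, in a 2.3-fold lower number from compound 2 to compound 3 (0.36 log units; beyond the scatter). That step was modest, however, and involved a different starting position. The closest group to the new one is the 2-(trifluoromethyl)phenyl of compound 1, and a 1.3-fold higher number from compound 1 to compound 3 (0.11 log units; within the scatter) suggests little separation.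

I therefore expect no step beyond the scatter, and the estimated change is a 1.1-fold lower number from compound 3 to compound 4 (0.03 log units; within the scatter). The expected value for compound 4 is 21000 nM, with an estimated range from 9000 nM to 48000 nM.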

Compound 4, half-maximal inhibitory concentration: 16000 nM
Compound 4: the middle estimate sits 1.3-fold (0.12 log units) above what was measured, and the stated range covers the measured number.
By their numbers in this assay, from the lowest: compounds 4, 1 and 3 (each within the scatter of the next); then compound 2.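

With all three placements of the trifluoromethoxy group now in hand, 2-(trifluoromethoxy)phenyl and 3-(trifluoromethoxy)phenyl on the sulfonyl sulfur cannot be told apart, with a 1.4-fold lower number from compound 3 to compound 4 (0.15 log units; within the scatter), whereas 4-(trifluoromethoxy)phenyl stands clearly apart from the new group, with a 3.2-fold lower number from compound 2 to compound 4 (0.51 log units; beyond the scatter); among these three compounds, then, only compound 2 separates from the others. The set also gains its first direct comparison of trifluoromethoxy with trifluoromethyl on an aromatic carbon, and in this one pair the swap leaves no difference that can be distinguished from assay scatter, with a 1.1-fold lower number from compound 1 to compound 4 (0.04 log units; within the scatter). Nothing available here explains why compound 2 stands apart from compound 3 and compound 4.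

Whether trifluoromethyl would follow the same pattern remains open, since it appears here only as 2-(trifluoromethyl)phenyl, and 3-(trifluoromethyl)phenyl and 4-(trifluoromethyl)phenyl are absent from the compounds shown. Also open, going by these compounds, is what a quite different substituent on the aromatic ring, such as an amine, a nitrile or a carboxylic acid, would do, and how much the unchanged remainder of the shared core contributes.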